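The source may report more compounds than this note shows. Statements on the series, on what has been measured and on what is new or still open speak of the compounds shown alone.

Measured compounds:
- compound 1, `CCCc1cc(N)c2cc(NC(=O)/C=C/c3ccc(N)cc3)ccc2n1`, 190 nM in an assay on isolated protein for displacement of a labelled ligand from melanin-concentrating hormone receptor 1 (Homo sapiens); a lower number here means a stronger inhibitor, a higher number a weaker inhibitor
- compound 2, `CCCc1cc(NC2CC2)c2cc(NC(=O)/C=C/c3ccc(C(F)(F)F)cc3)ccc2n1`, 40 nM in this assay
- compound 3, `CCCc1cc(N)c2cc(NC(=O)c3ccc(-c4ccc(Cl)cc4)cc3)ccc2n1`, 0.7 nM in this assay

Compound 1 stands at the highest of the three numbers in this assay, and so is the weakest inhibitor among them. Compound 2 is the nearest to it, with a lower number, a gap beyond the usual scatter; compound 3 is the furthest away, with a much lower number, also beyond the scatter.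

Compound 4, `CCCCc1ccc(/C=C/C(=O)Nc2ccc3nc(CCC)cc(N)c3c2)cc1`, is not yet measured. It differs from compound 1 in one place: butyl in place of amino on an aromatic carbon. Among the measured compounds shown here, no single-change step between measured compounds matches this exchange, so the expectation must rest on the whole set. Compounds 2 and 3 each carry a group other than amino at the corresponding place on the outer ring, though both also differ elsewhere from compound 1, so their lower numbers cannot be tied to that place alone.

The step from compound 1 to compound 4 is expected to be a moderate one downward, beyond the scatter, as a 3.8-fold lower number from compound 1 to compound 4 (0.58 log units; beyond the scatter). Compound 4 is expected to give about 50 nM in this assay, with a likely range from 12 nM to 200 nM.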

Compound 4, half-maximal inhibitory concentration: 45 nM
For compound 4 the middle estimate is 1.1-fold (0.05 log units) above the measured one, within the range that was stated.
By their numbers in this assay, from the lowest: compound 3; then compounds 2 and 4 (each within the scatter of the next); then compound 1.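

In this assay, among the compounds shown here, putting butyl in place of amino on this six-membered aromatic ring of carbon only gives a 4.2-fold lower number from compound 1 to compound 4 (0.63 log units; beyond the scatter), the first change at this place that can be read on its own. For this pair, then, the amino group is not needed at this place: a chain of four carbons, with no hydrogen-bond donor or acceptor, gives the lower number. Nothing measured here explains why the number falls.

The compounds shown leave open how the number would respond to a shorter chain such as ethyl, a longer one such as hexyl, or a group carrying oxygen such as methoxy at this place. They also leave open whether the same exchange would give a similar step if the amino group on the shared core were replaced by a cyclopropyl-bearing amine.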